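A trifluoromethyl swap on a weak growth inhibitor

The source may hold more compounds than are shown below. What is called first, only, known or untested is meant among the compounds shown, and "the series" means these compounds.

Measured in a functional assay on PC-3 cells (Homo sapiens); a lower number here means a stronger inhibitor of growth, a higher number a weaker inhibitor of growth:
Compound 1 `O=S(=O)(/C=C/c1ccc(Cl)cc1Cl)Cc1ccc(Nc2ncnc3ccccc23)cc1`: 19000 nM
Compound 2 `O=S(=O)(/C=C/c1ccc(F)cc1F)Cc1ccc(Nc2ncnc3ccccc23)cc1`: > 100000 nM

Compound 2 stands at > 100000 nM, which is a limit of the assay and not a number. Compound 3 `O=S(=O)(/C=C/c1ccc(C(F)(F)F)cc1F)Cc1ccc(Nc2ncnc3ccccc23)cc1` carries trifluoromethyl in place of fluoro on an aromatic carbon, para to a large group: trifluoromethyl in place of fluoro on an aromatic carbon. Going by the values given here, one measured step bears on this change: an at least 5.2-fold higher number from compound 1 to compound 2 (0.72 log units; beyond the scatter). This step also replaced a group at that place, and it suggests a modest move in this assay toward a lower number. The expected change is an at least 2.5-fold lower number from compound 2 to compound 3 (0.39 log units; beyond the scatter), though a reading at the limit remains possible. For compound 3 the estimate is 40000 nM, with an expected range of 12000 nM to 100000 nM.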

Compound 3, concentration for 50% growth inhibition: 100000 nM
Compound 3: the middle estimate sits 2.5-fold (0.40 log units) below what was measured, and the stated range covers the measured number.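

In this assay trifluoromethyl in place of fluoro on this aromatic carbon gives a number no higher from compound 2 to compound 3 (the limit leaves the size open). The size of this step cannot be read, because compound 2 stands at a limit of the assay and not at a number: the limit of > 100000 nM in this assay, at which 1 of the 3 values shown sits.

The readable comparison at this place has 2-fluoro-4-(trifluoromethyl)phenyl in place of 2,4-dichlorophenyl and gives a 5.3-fold higher number from compound 1 to compound 3 (0.72 log units; beyond the scatter). Trifluoromethyl on this aromatic carbon, para to a large group, therefore does not reach the level of compound 1.

From the compounds shown here alone, whether an amine, a carboxylic acid or a methoxy group at this place would give a lower number than compound 1 remains open.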